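The compounds below may be only part of what the source reports. "The series", "measured", "known", "first", "only" and "open" are said of these compounds alone.

Compound 1 (`O=C(/C=C/c1ccc([N+](=O)[O-])cc1)Nc1cc2c(Nc3ccc(F)c(Cl)c3)ncnc2cc1O[C@H]1CCOC1`), compound 2 (`O=C(/C=C/c1cccc(Cl)c1Cl)Nc1cc2c(Nc3ccc(F)c(Cl)c3)ncnc2cc1O[C@H]1CCOC1`) and compound 3 (`COc1cc(/C=C/C(=O)Nc2cc3c(Nc4ccc(F)c(Cl)c4)ncnc3cc2O[C@H]2CCOC2)cc(OC)c1OC`) share one core and differ only in the group on a double-bonded chain carbon bound to a double-bonded chain carbon. In a functional assay on MCF7 cells (Homo sapiens) for cytotoxicity, read by MTT assay, with a stated time of 72 h (on this read-out higher numbers stand for weaker inhibition and lower numbers for stronger inhibition), the three give close numbers: compound 1 (26700 nM), compound 2 (30100 nM) and compound 3 (28400 nM). Compound 3 therefore lies within the scatter of both others and holds no distinct rank among them.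

Compound 4 (`N#Cc1ccc(/C=C/C(=O)Nc2cc3c(Nc4ccc(F)c(Cl)c4)ncnc3cc2O[C@H]2CCOC2)cc1`) has not yet been measured. It differs from compound 3 at that same place (4-cyanophenyl in place of 3,4,5-trimethoxyphenyl on a double-bonded chain carbon bound to a double-bonded chain carbon), with 4-cyanophenyl in place of 3,4,5-trimethoxyphenyl.

The best guides are the three measured steps that exchange one group for another at this place (a 1.1-fold higher number from compound 1 to compound 3 (0.03 log units; within the scatter)), (a 1.1-fold lower number from compound 2 to compound 3 (0.03 log units; within the scatter)) and (a 1.1-fold higher number from compound 1 to compound 2 (0.05 log units; within the scatter)). All three are very small, even though the groups exchanged are quite different. On that basis, no step beyond the scatter is expected in this assay for this new exchange (a 1.0-fold lower number from compound 3 to compound 4 (0.01 log units; within the scatter)). However, three compounds are a small sample, and none of them carries the 4-cyanophenyl group, so the range is kept generous. For compound 4 the expected value is 28000 nM (estimated range 15000 nM to 50000 nM).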

Compound 4, half-maximal inhibitory concentration: 9830 nM
Estimate against measurement, compound 4: 2.8-fold (0.45 log units) above; the whole stated range lies above it.
By their numbers in this assay, from the lowest: compound 4; then compounds 1, 3 and 2 (each within the scatter of the next).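

In this assay this place turns out not to be indifferent to the group it carries: three quite different groups gave numbers within the scatter of one another, yet 4-cyanophenyl gives a clear change against each of them (a 2.9-fold lower number from compound 3 to compound 4 (0.46 log units; beyond the scatter)), (a 3.1-fold lower number from compound 2 to compound 4 (0.49 log units; beyond the scatter)) and (a 2.7-fold lower number from compound 1 to compound 4 (0.43 log units; beyond the scatter)). The last of these steps is the most telling, as cyano in place of nitro on an aromatic carbon is the only difference, so one small exchange moves the number when the larger exchanges among compounds 1, 2 and 3 did not. Compound 4 is thus the strongest of the four on this read-out, though the steps are modest, and no measurement is at hand to say what sets the 4-cyanophenyl group apart.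

The compounds shown leave open whether this gain belongs to the cyano group alone, or whether an amine, a carboxylic acid or a trifluoromethyl group in its place would do the same. They also leave open where an unsubstituted phenyl group would fall, with compound 4 or with the other three.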